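Swapping a pyridylmethoxy group for an isothiazolylmethoxy group

The source may report more compounds than this note shows. Statements on the series, on what has been measured and on what is new or still open speak of the compounds shown alone.

Of the compounds shown here, two from this series have been tested in an assay on cerebellum for binding affinity to Endothelin receptor type B (Rattus norvegicus); a lower number here means a stronger inhibitor, a higher number a weaker inhibitor. Compound 1 `Cc1ccccc1C(CCC(=O)O)Oc1cc(OCc2ccsc2)ccc1-c1ncc[nH]1` carries a thiophenylmethoxy group together with an imidazole on its core; in this assay compound 1 reaches only the limit of > 10000 nM, a limit of the assay rather than a number. Among the measured compounds shown here, compound 2 `Cc1ccccc1[C@@H](CCC(=O)O)Oc1cc(OCc2cccnc2)ccc1C#N` bears a nitrile on the core and a pyridin-3-ylmethoxy group; in this assay compound 2 gives 10000 nM, the only numeric value among the two. The other value, that of compound 1, sits at the limit (the limit of > 10000 nM in this assay, at which 1 of the 2 values shown sits). Compound 3 `Cc1ccccc1[C@@H](CCC(=O)O)Oc1cc(OCc2cnsc2)ccc1C#N` differs from compound 2 in one place: 1,2-thiazol-4-yl in place of pyridin-3-yl on a saturated chain carbon bound to an oxygen on an aromatic ring. For the measured compounds named here, no measured pair shows this change, so the author expects a step of no change at the digits printed from compound 2 to compound 3 (within the scatter) no larger than the scatter, in either direction. Compound 3 is therefore estimated at 10000 nM, in the range 3000 nM to 30000 nM.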

Compound 3, half-maximal inhibitory concentration: 10000 nM
Compound 3: middle estimate and measured number agree at the digits printed; the range from low to high includes it.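

In this assay, putting 1,2-thiazol-4-yl in place of pyridin-3-yl on a saturated chain carbon bound to an oxygen on an aromatic ring gives no change at the digits printed from compound 2 to compound 3 (within the scatter). Among the compounds shown here, this is the first step between compounds that differ in one place, and it shows that a five-membered aromatic ring with two hetero atoms and a six-membered aromatic ring with one read alike here. The reading says little about how sensitive this place is, since both numbers lie at the edge of what the assay reports: the limit of > 10000 nM in this assay, at which 1 of the 3 values shown sits.

As far as these compounds go, whether an open-chain group such as a longer chain ending in an amine would shift the value at this place remains open. So does whether the same swap would read alike with an imidazole on the core instead of the nitrile.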